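This account rests on a few compounds, and the source may have more. Where it says the series, first, only, none or still open, it means among the compounds named here.

Compound 1 `CC(CCO)n1cnc2c(Cl)ncnc21`: > 50000 nM (a limit)
Compound 2 `CCCCCCC(CCO)n1cnc2c(Cl)ncnc21`: 16700 nM

In a functional assay on SW480 cells (Homo sapiens) for antiproliferative activity, read by MTT assay, with a stated time of 48 h (a higher number here means a weaker inhibitor, a lower number a stronger inhibitor), compound 1 gives > 50000 nM, which is a limit of the assay and not a number. Within the data shown here, compound 2 gives 16700 nM, the only true number so far. The next compound, compound 3 `CCCCCCC(CCO)n1cnc2c(NC)ncnc21`, has methylamino in place of chloro on an aromatic carbon. Among the measured compounds shown here, the one measured step, an at least 2.9-fold lower number from compound 1 to compound 2 (0.47 log units; beyond the scatter), put pentyl in place of hydrogen on a saturated chain carbon and left the chloro untouched. For the measured compounds named here, it therefore says nothing directly about this exchange, and no step at this place has been measured. No step beyond the usual scatter of this assay is firmly expected, only a slight lean toward a weaker number. The estimated step is a 1.5-fold higher number from compound 2 to compound 3 (0.18 log units; within the scatter). For compound 3 the estimated value is 25000 nM, with an expected range from 8000 nM to 60000 nM.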

Compound 3, half-maximal inhibitory concentration: > 50000 nM
Compound 3: only a limit was reported; the forecaster's own chance of this, stated with the estimate: 35%; at least 2.0-fold (0.30 log units) between middle value and limit.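

Methylamino in place of chloro on an aromatic carbon gives an at least 2.9-fold higher number from compound 2 to compound 3 (0.47 log units; beyond the scatter) in this assay, so this is the first measured sign that this position matters: with the hexyl-type chain of the series unchanged, the chloro cannot be swapped for methylamino without losing the measurable activity. The reading for compound 3 is a limit and not a number, so the step has a smallest size but no known full size. Any further weakening in this series would be hard to see at this ceiling: the limit of > 50000 nM in this assay, at which 2 of the 3 values shown sit.

As far as these compounds go, whether the loss follows from methylamino in particular or from any nitrogen group at this carbon stays open, and a plain amine or a dimethylamino group would speak to that. From the compounds shown here alone, whether another halogen, such as bromo, could stand in for chloro also stays open.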